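Replacing a methyl group with ((dichloromethyl)carbonyl)amino

The source may hold more compounds than are shown below. What is called first, only, known or untested is meant among the compounds shown, and "the series" means these compounds.

In a functional assay on KB 3-1 cells (Homo sapiens) for cytotoxicity, read by MTT assay, with a stated time of 68 h (a lower number here means a stronger inhibitor, a higher number a weaker inhibitor), compound 1 `Nc1cccc(-c2cccc(NC(=O)C(Cl)Cl)c2)c1` gives 26100 nM and compound 2 `COc1cccc(-c2cccc(NC(=O)C(Cl)Cl)c2)c1` gives 43300 nM. The gap between them, a 1.7-fold higher number from compound 1 to compound 2 (0.22 log units; within the scatter), is small. Compound 3 `Cc1cccc(-c2cccc(NC(=O)C(Cl)Cl)c2)c1` gives > 50000 nM, which is a limit and not a true number. Compound 4 `O=C(Nc1cccc(-c2cccc(NC(=O)C(Cl)Cl)c2)c1)C(Cl)Cl` has ((dichloromethyl)carbonyl)amino in place of methyl on an aromatic carbon. Two measured steps involve the same methyl group: an at least 1.9-fold higher number from compound 1 to compound 3 (0.28 log units; that floor lies within the scatter) and an at least 1.1-fold higher number from compound 2 to compound 3 (0.06 log units; that floor lies within the scatter). Both are only floors within the scatter, and neither involves the entering group, so only a modest move towards a lower number is expected. The expected change is an at least 1.6-fold lower number from compound 3 to compound 4 (0.22 log units; that floor lies within the scatter). For compound 4, the estimated value is 30000 nM, with an expected range of 8000 nM to 50000 nM.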

Compound 4, half-maximal inhibitory concentration: > 50000 nM
Compound 4 gave a limit, no number; the forecaster's own chance of this, stated with the estimate: 35%; at least 1.6-fold (0.22 log units) between middle value and limit.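

In this assay compound 4 gives > 50000 nM, which is a limit and not a number, so ((dichloromethyl)carbonyl)amino on this aromatic carbon yields no measurable potency here. The step from methyl to this group cannot be read, since both values are limits: the limit of > 50000 nM in this assay, at which 2 of the 4 values shown sit. The readable comparisons are an at least 1.1-fold higher number from compound 2 to compound 4 (0.06 log units; that floor lies within the scatter) and an at least 1.9-fold higher number from compound 1 to compound 4 (0.28 log units; that floor lies within the scatter), and these floors give no firm ranking of compound 4 against the methoxy and amino compounds.

Going by these compounds, how far the true values of compound 3 and compound 4 lie beyond the limit stays open. So does whether a carboxylic acid or a longer alkyl chain on this aromatic carbon would give a true number.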